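The compounds below may be only part of what the source reports. "The series", "measured", "known", "first", "only" and "open" are said of these compounds alone.

In an assay on CHO-K1 cells for displacement of a labelled ligand from Neuronal acetylcholine receptor; alpha4/beta2 (Homo sapiens), read by scintillation counting (on this read-out higher numbers stand for weaker inhibition and lower numbers for stronger inhibition), compound 1 `CN1[C@H](COc2cncc(Cl)c2)C[C@H]2C[C@H]21` gives 0.37 nM, while compound 2 `CN1[C@H](COc2cccnc2)C[C@H]2C[C@H]21` gives 5.5 nM. The change between them is chloro in place of hydrogen on an aromatic carbon, and it made a 15-fold lower number from compound 2 to compound 1 (1.17 log units; beyond the scatter). Compound 3 `c1cncc(OC[C@]23C[C@H]2CCN3)c1` is built on a different core from compound 2; how the two cores differ is not broken down here. In this assay compound 3 gives 242 nM, the highest of the three. Compound 4 `Clc1cncc(OC[C@]23C[C@H]2CCN3)c1` has not yet been measured; it differs from compound 3 by chloro in place of hydrogen on an aromatic carbon. This is the same kind of change as that from compound 2 to compound 1, though the place is not identical: here the chloro sits meta to a group of 8 heavy atoms rather than 9. Resting on a 15-fold lower number from compound 2 to compound 1 (1.17 log units; beyond the scatter), compound 4 is expected to show a 12-fold lower number from compound 3 to compound 4 (1.08 log units; beyond the scatter). Compound 4 is therefore estimated at 20 nM, likely between 6 nM and 80 nM.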

Compound 4, inhibition constant: 827 nM
Compound 4: middle estimate off by 41-fold (1.62 log units), on the low side; the whole stated range lies below it.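

In this assay the chloro on the core of compound 3 gives a 3.4-fold higher number from compound 3 to compound 4 (0.53 log units; beyond the scatter) and so runs opposite to the same change on the core of compound 2, which gave a 15-fold lower number from compound 2 to compound 1 (1.17 log units; beyond the scatter) for the pair it links. A gain seen on one core therefore did not carry over to the other, and the two steps clearly differ: the same change on two cores in this assay, a 15-fold lower number (1.17 log units; beyond the scatter) from compound 2 to compound 1 and a 3.4-fold higher number (0.53 log units; beyond the scatter) from compound 3 to compound 4, 51-fold (1.71 log units) apart, beyond the scatter of two such steps. Two pairs cannot show why the cores part ways, nor how a third core would respond.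

From the compounds shown here alone, it remains open whether bromo, methyl or methoxy in the same place would follow the chloro on each core. Going by these compounds, it also remains open whether any such group would lower the number on the core of compound 3.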